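Chloro in place of nitro: an estimate

The compounds below may be only part of what the source reports. "The series", "measured", "known", "first", "only" and "open" are said of these compounds alone.

Among the compounds with values here, in an ADME assay (Rattus norvegicus) for metabolic stability (on this read-out lower numbers stand for a shorter-lived compound and higher numbers for a longer-lived compound), compound 1 (`O=C(O)[C@@H](CC1CCC1)N1C[C@H](CN2CCC(c3cnc4ccc([N+](=O)[O-])cn34)CC2)[C@@H](c2cccc(F)c2)C1`) gives 0.2 h as the lowest of the three numbers measured so far. Compound 2 (`CCc1ccn2c(C3CCN(C[C@H]4CN([C@H](CC5CCC5)C(=O)O)C[C@@H]4c4cccc(F)c4)CC3)cnc2c1`) gives 2.5 h and compound 3 (`O=C(O)[C@@H](CC1CCC1)N1C[C@H](CN2CCC(c3cnc4ccc(-c5ccccc5)cn34)CC2)[C@@H](c2cccc(F)c2)C1`) gives 1.6 h in the same read-out. Compound 4 (`O=C(O)[C@@H](CC1CCC1)N1C[C@H](CN2CCC(c3cnc4ccc(Cl)cn34)CC2)[C@@H](c2cccc(F)c2)C1`) is still unmeasured and has chloro in place of nitro on an aromatic carbon. Within the data shown here, two measured steps bear on this change, and both lead upward: phenyl in place of nitro gave an 8.0-fold higher number from compound 1 to compound 3 (0.90 log units; beyond the scatter) as its step, and the wider change gave a 13-fold higher number from compound 1 to compound 2 (1.10 log units; beyond the scatter) as its step. Neither of them involves chloro, so the size remains uncertain. An upward step somewhat smaller than these is expected in this assay, estimated as a 5.0-fold higher number from compound 1 to compound 4 (0.70 log units; beyond the scatter) for this change. The expected number for compound 4 is 1 h with an estimated range of 0.4 h to 2.5 h in this read-out.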

Compound 4, half-life: 0.7 h
Beside the measured number, compound 4's estimate is 1.4-fold (0.15 log units) above it, within the range that was stated.
By their numbers in this assay, from the lowest: compound 1; then compound 4; then compounds 3 and 2 (each within the scatter of the next).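

In this assay chloro in place of nitro gives a 3.5-fold higher number from compound 1 to compound 4 (0.54 log units; beyond the scatter) and so a higher number at this aromatic carbon does not need a ring in the entering group. Phenyl still ends higher than chloro, as a 2.3-fold lower number from compound 3 to compound 4 (0.36 log units; beyond the scatter) shows, and the wider change of group on the saturated ring carbon gives a 3.6-fold lower number from compound 2 to compound 4 (0.55 log units; beyond the scatter) as well. Nothing measured here explains these steps. The compounds shown leave open what an amine or a methoxy group on this aromatic carbon would give. They also leave open whether fluoro would land near chloro.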